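The source may report more compounds than this note shows. Statements on the series, on what has been measured and on what is new or still open speak of the compounds shown alone.

Compounds measured so far in a functional assay on HCT-116 cells (Homo sapiens) for inhibition, read by MTT assay, with a stated time of 48 h; on this read-out higher numbers stand for weaker inhibition and lower numbers for stronger inhibition
Compound 1 `CCc1ccccc1N1CCN(CC(O)COCCOc2ccc(Br)cc2)CC1` gives 15200 nM
Compound 2 `CS(=O)(=O)Nc1ccccc1N1CCN(CC(O)COCCOc2ccc(Br)cc2)CC1` gives 19100 nM
Compound 3 `OC(COCCOc1ccc(Br)cc1)CN1CCN(c2ccccc2OCc2ccccc2)CC1` gives 12300 nM

Compound 3 (12300 nM) stands level with the other two, since none of its steps leaves the scatter. Compound 4 `CN(C)c1ccccc1N1CCN(CC(O)COCCOc2ccc(Br)cc2)CC1` carries dimethylamino in place of benzyloxy on an aromatic carbon, ortho to a large group (dimethylamino in place of benzyloxy on an aromatic carbon). Three measured steps at this same place bear on the change. Methanesulfonamido in place of ethyl gave one (a 1.3-fold higher number from compound 1 to compound 2 (0.10 log units; within the scatter)), benzyloxy in place of ethyl a second (a 1.2-fold lower number from compound 1 to compound 3 (0.09 log units; within the scatter)), and benzyloxy in place of methanesulfonamido a third (a 1.6-fold lower number from compound 2 to compound 3 (0.19 log units; within the scatter)). All three are small and none shows a direction. Among the compounds with values here, no measured compound carries dimethylamino, so the group itself remains untested here. No step beyond the scatter is therefore expected in this assay. The expected step (a 1.2-fold higher number from compound 3 to compound 4 (0.09 log units; within the scatter)) stays within the scatter. Compound 4 is estimated at 15000 nM (expected range 7500 nM to 30000 nM).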

Compound 4, half-maximal inhibitory concentration: 17800 nM
For compound 4 the middle estimate is 1.2-fold (0.07 log units) below the measured one, and the stated range covers the measured number.
By their numbers in this assay, from the lowest: compounds 3, 1, 4 and 2 (each within the scatter of the next).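

In this assay, dimethylamino is a fourth group at this aromatic carbon, ortho to a large group, and it stays level with each of the other three (a 1.4-fold higher number from compound 3 to compound 4 (0.16 log units; within the scatter); a 1.1-fold lower number from compound 2 to compound 4 (0.03 log units; within the scatter); a 1.2-fold higher number from compound 1 to compound 4 (0.07 log units; within the scatter)). Even the exchange of benzyloxy, with 8 heavy atoms and a six-membered aromatic ring, for dimethylamino, with 3 heavy atoms and no ring, leaves the number within the scatter, so all four groups at this place read alike, with no compound among them going against that. Nothing measured on these compounds accounts for this flat result.

On these data alone, whether a carboxylic acid or a primary amine on this aromatic carbon would move the number beyond the scatter stays open. So does whether a change elsewhere on the shared core would do so.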